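Chloro for methyl, starting from a limit

The source may report more compounds than this note shows. Statements on the series, on what has been measured and on what is new or still open speak of the compounds shown alone.

In a functional assay on MDA-MB-231 cells (Homo sapiens) for antiproliferative activity, read by MTT assay, with a stated time of 72 h (on this read-out higher numbers stand for weaker inhibition and lower numbers for stronger inhibition), compound 1 `O=c1oc2cc(O)ccc2cc1-c1ccc(O)cc1` gives > 100000 nM, which is a limit of the assay and not a number. Compound 2 `Cc1cc(O)ccc1-c1c(C)c2ccc(O)cc2oc1=O` gives > 100000 nM, which is also a limit, so it offers no exact starting point. The two compounds shown so far both stand at the limit of > 100000 nM in this assay, at which 2 of the 2 values shown sit.

Compound 3 `Cc1c(-c2ccc(O)cc2Cl)c(=O)oc2cc(O)ccc12` has not yet been measured. It differs from compound 2 by a single swap, chloro in place of methyl on an aromatic carbon, ortho to a large group and meta to a hydroxy group. Within the data shown here, no measured pair shows what this swap does. The expected change, a number no higher from compound 2 to compound 3 (the limit leaves the size open), is therefore none beyond the usual scatter, and another limit is the likeliest report. The estimated value for compound 3 is 100000 nM, with an expected range from 30000 nM to 200000 nM.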

Compound 3, half-maximal inhibitory concentration: 46100 nM
Estimate against measurement, compound 3: 2.2-fold (0.34 log units) above; low and high end bracket the measured number.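

In this assay, among these compounds, chloro in place of methyl on the aromatic carbon gives the first exact number in this set, with an at least 2.1-fold lower number from compound 2 to compound 3 (0.33 log units; beyond the scatter). This shows that the position, ortho to a large group and meta to a hydroxy group, can respond to a single swap, which the two earlier compounds could not show. The size of the step stays unknown and most of the values still give no exact number, so the activity measured here is only a first foothold: the limit of > 100000 nM in this assay, at which 2 of the 3 values shown sit.

The compounds shown leave open whether the step comes from the arrival of chloro or from the departure of methyl. They also leave open how bromo, methoxy or an amine on the same carbon would read in this assay.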